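This account rests on a few compounds, and the source may have more. Where it says the series, first, only, none or still open, it means among the compounds named here.

Compound 3, `CCCCNc1nc(N)nc2cccc(OCc3ccccn3)c12`, is evaluated in an ADME assay on HEK293 cells for agonist activity at Toll-like receptor 8 (Homo sapiens), read by a luciferase reporter, with a stated time of 6 h; a lower number here means that less compound is needed, a higher number that more compound is needed for the effect; in that assay compound 3 gives 18.5 uM. Among the numbers shown, compound 3 stands highest; its nearest neighbour is compound 2, `CCCCNc1nc(N)nc2cccc(CCc3ccccc3)c12`, which gives 0.47 uM, and the step of a 39-fold higher number from compound 2 to compound 3 (1.60 log units; beyond the scatter) is large. Compound 1, `CCCCNc1nc(N)nc2cccc(CC3CCCC3)c12`, reaches only a limit of this assay, > 25 uM. Among the measured compounds shown here, two steps bear on the arm at this position: an at least 53-fold lower number from compound 1 to compound 2 (1.72 log units; beyond the scatter) and an at least 1.3-fold lower number from compound 1 to compound 3 (0.13 log units; that floor lies within the scatter), the first far beyond the scatter and the second pinned to the limit described by the limit of > 25 uM in this assay, at which 1 of the 3 values shown sits. The change to compound 4, `CCCCNc1nc(N)nc2cccc(C(=O)N(C)C(C)C)c12`, is isopropyl(methyl)carbamoyl in place of (pyridin-2-yl)methoxy on an aromatic carbon. For the measured compounds named here, no measured compound carries an isopropyl(methyl)carbamoyl arm, so the steps show only that this position shifts the read-out strongly in either direction. He therefore expects no step beyond the scatter, with an estimated 1.3-fold lower number from compound 3 to compound 4 (0.12 log units; within the scatter). For compound 4 the estimated value in this assay is 14 uM, expected to lie between 3 uM and 60 uM.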

Compound 4, minimum effective concentration: > 25 uM
Compound 4 was reported as a limit; the forecaster's own chance of this, stated with the estimate: 35%; at least 1.7-fold (0.25 log units) between middle value and limit.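

Compound 4 ends at a limit in this assay, not at a number: the limit of > 25 uM in this assay, at which 2 of the 4 values shown sit.

Set against phenethyl, the isopropyl(methyl)carbamoyl arm gives an at least 53-fold higher number from compound 2 to compound 4 (1.72 log units; beyond the scatter), so a second arm without a ring joins cyclopentylmethyl far from compound 2, while compound 3, which does carry an aromatic ring, also stands far from compound 2. Against (pyridin-2-yl)methoxy the same arm gives an at least 1.3-fold higher number from compound 3 to compound 4 (0.13 log units; that floor lies within the scatter), a floor within the scatter, so these two arms cannot be told apart here, and the step between compound 1 and compound 4 cannot be read.

The compounds shown leave open whether a benzyl amide, which would keep a phenyl ring on a carbonyl-bearing arm, comes back towards compound 2. They also leave open how a plain butyl chain or an aminomethyl group would behave at this place.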